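A few compounds are considered here, and "the series" means these few. Any claim that something is new, unique, unknown or untested is made for them only; others in the source may bear on it.

Compound 1 `CC(C)C[C@H](N)COc1ccc(-c2ccnc(N)c2)cc1` sits second highest among the three numbers shown. In an assay on isolated protein for inhibition of AP2-associated protein kinase 1 (Homo sapiens), with a stated time of 3 h, in the presence of a further agent that is not named here (on this read-out lower numbers stand for stronger inhibition and higher numbers for weaker inhibition), compound 1 gives 21 nM, compound 2 `COC(=O)Nc1cc(-c2ccc(OC[C@@](C)(N)CC(C)C)c(C)c2C)ccn1` gives 4.5 nM, and compound 3 `COC(=O)Nc1cc(-c2cnc(OC[C@@](C)(N)CC(C)C)cc2C)ccn1` gives 490 nM. Within the data shown here, no single-change pair has been measured here, so no measured step can be quoted. Compound 4 `CC(=O)Nc1cc(-c2ccc(OC[C@@H](N)CC(C)C)cc2)ccn1` differs from compound 1 in one place: acetyl in place of hydrogen on a nitrogen on an aromatic ring. Compound 2 also carries an acyl group on this nitrogen while giving 4.5 nM, though it differs from compound 1 in further places, so only a loose hint can be drawn. The step from compound 1 to compound 4 is expected to be small, toward a lower number, roughly at the edge of the scatter, as a 2.1-fold lower number from compound 1 to compound 4 (0.32 log units; beyond the scatter). Compound 4 is expected to give about 10 nM, between 3 nM and 40 nM.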

Compound 4, half-maximal inhibitory concentration: 4.6 nM
Beside the measured number, compound 4's estimate is 2.2-fold (0.34 log units) above it, and the stated range covers the measured number.
By their numbers in this assay, from the lowest: compounds 2 and 4 (each within the scatter of the next); then compound 1; then compound 3.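

In this assay, replacing amino with acetamido gives a 4.6-fold lower number from compound 1 to compound 4 (0.66 log units; beyond the scatter) and so shows directly that this nitrogen on the aromatic ring can carry an acetyl group with a modest gain. Until now, only a loose hint from compound 2, which differs from compound 1 in further places, pointed that way. Nothing measured here explains the gain.

As far as these compounds go, it remains open whether a propanoyl group, with its longer chain, or a methanesulfonyl group on this nitrogen would behave like acetyl. From the compounds shown here alone, a simple methyl group there is equally open.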